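Moving the Chlorine on the Aryl Ester

The source may hold more compounds than are shown below. What is called first, only, known or untested is meant among the compounds shown, and "the series" means these compounds.

Compound 1 `COC(=O)c1cc(Cl)ccc1OC(=O)COc1cc(O)c2c(=O)cc(-c3ccccc3)oc2c1`: 3740 nM
Compound 2 `COC(=O)c1cccc(C)c1OC(=O)COc1cc(O)c2c(=O)cc(-c3ccccc3)oc2c1`: 39100 nM
Compound 3 `COC(=O)c1ccc(Cl)cc1OC(=O)COc1cc(O)c2c(=O)cc(-c3ccccc3)oc2c1`: 12400 nM

Three compounds share one core and differ only in the aryl group on an oxygen next to a carbonyl group. In a functional assay on cells (T-cell, Mus musculus, strain BALB/c) for inhibition, read by MTT assay, with a stated time of 72 h (on this read-out higher numbers stand for weaker inhibition and lower numbers for stronger inhibition), compound 3 gives 12400 nM, the second highest of the three numbers: nearest is a 3.2-fold lower number from compound 2 to compound 3 (0.50 log units; beyond the scatter), furthest is a 3.3-fold higher number from compound 1 to compound 3 (0.52 log units; beyond the scatter). Compound 4 `COC(=O)c1cccc(Cl)c1OC(=O)COc1cc(O)c2c(=O)cc(-c3ccccc3)oc2c1` is not yet measured; its change from compound 3 is 2-chloro-6-(methoxycarbonyl)phenyl in place of 5-chloro-2-(methoxycarbonyl)phenyl on an oxygen next to a carbonyl group. Among the compounds with values here, no measured step places the chlorine where compound 4 carries it. The step of a 3.3-fold higher number from compound 1 to compound 3 (0.52 log units; beyond the scatter) shows that shifting the chlorine alone moves the number modestly, and compound 2 shows the weakest number of the set. A modest weakening is therefore expected, a 2.0-fold higher number from compound 3 to compound 4 (0.30 log units; within the scatter). Compound 4 is estimated at 25000 nM, with a range from 8000 nM to 80000 nM.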

Compound 4, half-maximal inhibitory concentration: 38700 nM
Compound 4: the middle estimate sits 1.5-fold (0.19 log units) below what was measured; the range from low to high includes it.
By their numbers in this assay, from the lowest: compound 1; then compound 3; then compounds 4 and 2 (each within the scatter of the next).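

With the chlorine placed as in 2-chloro-6-(methoxycarbonyl)phenyl, the number rises further than any earlier chlorine shift showed: a 3.1-fold higher number from compound 3 to compound 4 (0.49 log units; beyond the scatter), and a 10-fold higher number from compound 1 to compound 4 (1.01 log units; beyond the scatter). Chloro and methyl cannot be told apart here, with a 1.0-fold lower number from compound 2 to compound 4 (0.00 log units; within the scatter), so the high number of compound 2 is not peculiar to methyl. Nothing available explains why the placement of the chlorine matters. Still open, on these data alone, is whether an amine or a methoxy group at that place would match compound 4, and whether a carboxylic acid in place of the methyl ester would keep the same order among the chlorine compounds.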